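A few compounds are considered here, and "the series" means these few. Any claim that something is new, unique, unknown or untested is made for them only; others in the source may bear on it.

Series notes on solubility. Two compounds carry numbers in a physicochemical assay for solubility, read by LC-MS, in phosphate buffer, with a stated time of 24 h, at pH 7.4; on this read-out lower numbers stand for lower solubility and higher numbers for higher solubility. Compound 1 `Cc1cc(-c2cnc(NCc3c(F)ccc4c3CCO4)c3cn[nH]c(=O)c23)n(C)n1` gives 1000 nM in this assay, the lowest of the two numbers shown. Compound 2 `O=C1c2ccccc2CN1c1cnc(NCc2c(F)ccc3c2CCO3)n2cnnc12` gives 4000 nM in this assay, a higher number than compound 1, and the gap between the two lies beyond the scatter. Within the data shown here, no pair of measured compounds differs in a single place, so no measured step is available to lean on.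

Compound 3 `Cc1nc(CN(C)C)ccc1-c1cnc(NCc2c(F)ccc3c2CCO3)c2cn[nH]c(=O)c12` has not yet been measured in this assay. It differs from compound 1 in one place: 6-((dimethylamino)methyl)-2-methylpyridin-3-yl in place of 1,3-dimethyl-1H-pyrazol-5-yl on an aromatic carbon. The change sits on an aromatic carbon of the shared core, para to a large group.

Compound 3 is expected to give a higher number than compound 1 in this assay. The step of a 5.0-fold higher number from compound 1 to compound 3 (0.70 log units; beyond the scatter) is expected to lie beyond the scatter, toward a higher number. Compound 3 is estimated at 5000 nM, within a range from 1500 nM to 20000 nM.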

Compound 3, solubility: > 1000000 nM
Compound 3: no number, only a limit (the forecaster's own chance of this, stated with the estimate: 10%); middle value at least 200-fold (2.30 log units) from the limit.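

This is the first single-place step shown in the series: in this assay, 6-((dimethylamino)methyl)-2-methylpyridin-3-yl in place of 1,3-dimethyl-1H-pyrazol-5-yl on the aromatic carbon para to a large group gives an at least 1000-fold higher number from compound 1 to compound 3 (3.00 log units; beyond the scatter). Among these compounds, one replacement at this position is thus enough to move the read-out far beyond the scatter, which the earlier compounds could not show, as they offered no single-place step. The value for compound 3 is a limit of the assay and not a number: the limit of > 1000000 nM in this assay, at which 1 of the 3 values shown sits.

The compounds shown do not tell whether the step follows the six-membered ring or the (dimethylamino)methyl group on it. That question would need the same pyridine ring without this group, or with a morpholine or a carboxylic acid in its place.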